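Adding a second chloro to a benzyloxy amide series

A few compounds are considered here, and "the series" means these few. Any claim that something is new, unique, unknown or untested is made for them only; others in the source may bear on it.

Measured compounds:
Compound 1 `Cc1ccc(-c2nn(-c3ccccc3)cc2C(=O)NOCc2ccccc2)cc1`: 1870 nM
Compound 2 `Cc1ccc(-c2nn(-c3ccccc3)cc2C(=O)NOCc2ccccc2Cl)cc1`: 2640 nM
Compound 3 `O=C(NOCc1ccccc1Cl)c1cn(-c2ccccc2)nc1-c1ccc(F)cc1`: 11400 nM

All three were tested in a functional assay on MCF7 cells (Homo sapiens) for antiproliferative activity, read by MTT assay, with a stated time of 48 h, in the presence of a further agent that is not named here; on this read-out higher numbers stand for weaker inhibition of growth and lower numbers for stronger inhibition of growth. Compound 2 differs from compound 1 by chloro in place of hydrogen on an aromatic carbon. That change gave a 1.4-fold higher number from compound 1 to compound 2 (0.15 log units; within the scatter). Compound 3 is built on a different core; the difference between the two cores is not broken down here, but the step of a 4.3-fold higher number from compound 2 to compound 3 (0.64 log units; beyond the scatter) shows the cost of that change. The unmeasured compound 4 `O=C(NOCc1ccc(Cl)cc1Cl)c1cn(-c2ccccc2)nc1-c1ccc(F)cc1` differs from compound 3 by chloro in place of hydrogen on an aromatic carbon. This is the same kind of change as from compound 1 to compound 2, though not the same: there the new chloro sat ortho to a large group, here it sits meta to a chloro group and para to a large group. Given the small step from compound 1 to compound 2, compound 4 is expected to move by about a 1.2-fold higher number from compound 3 to compound 4 (0.09 log units; within the scatter) from compound 3. The estimate for compound 4 in this assay is 14000 nM, with a likely range from 5500 nM to 36000 nM.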

Compound 4, concentration for 50% growth inhibition: 25300 nM
Estimate against measurement, compound 4: 1.8-fold (0.26 log units) below, and the stated range covers the measured number.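

In this assay, the new chloro gave a 2.2-fold higher number from compound 3 to compound 4 (0.35 log units; beyond the scatter), so on this core the change costs some growth inhibition. Set beside the earlier step, this gives no sign that the change behaves differently on the two cores: the same change on two cores in this assay, a 1.4-fold higher number (0.15 log units; within the scatter) from compound 1 to compound 2 and a 2.2-fold higher number (0.35 log units; beyond the scatter) from compound 3 to compound 4, 1.6-fold (0.20 log units) apart, within the scatter of two such steps. Within the data shown here, that is not a rule for the series, however: it rests on a single pair of steps, only the step on the core of compound 3 lies beyond the scatter, and the chloro enters at a different place in each pair.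

The compounds shown leave open whether another group in place of the new chloro, such as a methoxy group or an amine, would follow the same course. Also open, going by these compounds, is how the 2,4-dichlorobenzyl group would behave on the core of compound 1, where only the benzyl and 2-chlorobenzyl groups appear.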